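From dimethylamino to 1,3-thiazol-2-yl on the benzyl group

The source may report more compounds than this note shows. Statements on the series, on what has been measured and on what is new or still open speak of the compounds shown alone.

In an ADME assay on MT4 cells (Homo sapiens) for cytotoxicity (a higher number here means that more compound is tolerated, a lower number that less compound is tolerated), compound 1 (`COC(=O)N[C@H](C(=O)NN(CCC[C@@](O)(Cc1ccccc1)C(=O)N[C@H]1c2ccccc2C[C@H]1O)Cc1ccccc1)C(C)(C)C`) gives > 10000 nM, which is a limit of the assay and not a number. Compound 2 (`COC(=O)N[C@H](C(=O)NN(CCC[C@](O)(Cc1ccccc1)C(=O)N[C@H]1c2ccccc2C[C@H]1O)Cc1ccc(Br)cc1)C(C)(C)C`) gives > 10000 nM, also a limit. Compound 3 (`COC(=O)N[C@H](C(=O)NN(CCC[C@@](O)(Cc1ccccc1)C(=O)N[C@H]1c2ccccc2C[C@H]1O)Cc1ccc(N(C)C)cc1)C(C)(C)C`) gives > 10000 nM, again a limit, so its standing is known only as a limit and it cannot be ranked against the other two.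

Compound 4 (`COC(=O)N[C@H](C(=O)NN(CCC[C@@](O)(Cc1ccccc1)C(=O)N[C@H]1c2ccccc2C[C@H]1O)Cc1ccc(-c2nccs2)cc1)C(C)(C)C`) carries 1,3-thiazol-2-yl in place of dimethylamino on an aromatic carbon.

For the measured compounds named here, the one measured step bearing on this change is a step that the two limits leave unreadable from compound 1 to compound 3. Going by the values given here, the series so far offers only (the limit of > 10000 nM in this assay, at which 3 of the 3 values shown sit). The step that the two limits leave unreadable from compound 1 to compound 3 gives no size to carry over, so no step beyond the scatter and no direction is expected in this assay. The estimated step is a step that the limit leaves unreadable from compound 3 to compound 4. For compound 4 the expected value is 20000 nM, with an estimated range from 8000 nM to 60000 nM. A report as a limit again is the likeliest outcome.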

Compound 4, half-maximal cytotoxic concentration: > 10000 nM
Compound 4 was reported as a limit (the forecaster's own chance of this, stated with the estimate: 80%); the middle value is on the limit's open side.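

In this assay, compound 4 joins compound 1 and compound 3 as a limit and not a number, so the steps from compound 3 and compound 1 to compound 4 cannot be read: the limit of > 10000 nM in this assay, at which 4 of the 4 values shown sit.

The compounds shown leave open whether 1,3-thiazol-2-yl in place of dimethylamino changes the tolerated concentration at all.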